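A few compounds are considered here, and "the series" means these few. Any claim that something is new, unique, unknown or untested is made for them only; others in the source may bear on it.

Measured so far:
compound 1, `Cn1c(CN2CCC(c3ccc(Cl)cc3)CC2)nc2ccccc21` — 79.4 nM
compound 2, `Cn1c(CN2CCC(c3ccccn3)CC2)nc2ccccc21` — a limit only, > 3160 nM
compound 3, `Cn1c(CN2CCC(c3ccccc3C(F)(F)F)CC2)nc2ccccc21` — 316 nM

In an assay on CHO cells with metabotropic glutamate receptor 2 (Homo sapiens) as the target, read by FLIPR (a higher number here means that more compound is needed for the effect, a lower number that less compound is needed), compound 3 carries the highest of the two numbers given as numbers, and compound 1 gives a clearly lower number. The value of compound 2 is a limit of this assay, not a number.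

Compound 4, `Cn1c(CN2CCC(c3ccccc3F)CC2)nc2ccccc21`, differs from compound 3 by fluoro in place of trifluoromethyl on an aromatic carbon. Going by the values given here, the only measured step, an at least 39-fold higher number from compound 1 to compound 2 (1.59 log units; beyond the scatter), swaps the whole aromatic ring and therefore says little about trimming one substituent. The step from compound 3 to compound 4 is thus expected to be modest, a small drop toward the number of compound 1, a 1.6-fold lower number from compound 3 to compound 4 (0.20 log units; within the scatter). Compound 4 is estimated at 200 nM, between 60 nM and 700 nM.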

Compound 4, half-maximal effective concentration: 126 nM
Compound 4: the middle estimate sits 1.6-fold (0.20 log units) above what was measured, within the range that was stated.
By their numbers in this assay, from the lowest: compounds 1 and 4 (each within the scatter of the next); then compound 3. At a limit, above all of these: compound 2.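

Going by these compounds alone, at this aromatic carbon, ortho to a large group, the change from trifluoromethyl to fluoro gives a 2.5-fold lower number from compound 3 to compound 4 (0.40 log units; beyond the scatter) and is the first measured step that alters one substituent alone. Comparing rings, 2-fluorophenyl against 4-chlorophenyl gives a 1.6-fold higher number from compound 1 to compound 4 (0.20 log units; within the scatter) and leaves the two unseparated. Compound 2 holds only a limit, so an at least 25-fold lower number from compound 2 to compound 4 (1.39 log units; beyond the scatter) is a bound rather than an exact step: the limit of > 3160 nM in this assay, at which 1 of the 4 values shown sits.

From the compounds shown here alone, whether a methoxy group or a nitrile at this carbon would keep or lower the number remains open. So does the effect of an amine there.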